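Cytotoxicity of a piperazinyl pyrimidine series: amide to dimethylphenyl

The compounds below may be only part of what the source reports. "The series", "measured", "known", "first", "only" and "open" are said of these compounds alone.

Compound 1 `CCOC(=O)c1cnc(N2CCN(Cc3ccc(C(F)(F)F)cc3)CC2)nc1Oc1c(C)cc(-c2ccc(C#N)cc2)cc1C`: > 125000 nM
Compound 2 `CCOC(=O)c1cnc(N2CCN(Cc3cccc(C(N)=O)c3)CC2)nc1Oc1c(C)cc(-c2ccc(C#N)cc2)cc1C`: 14800 nM
Compound 3 `CCOC(=O)c1cnc(N2CCN(Cc3cc(C)cc(C)c3)CC2)nc1Oc1c(C)cc(-c2ccc(C#N)cc2)cc1C`: not yet measured

Of the compounds shown here, two have been tested in an ADME assay on MT4 cells (Homo sapiens) for cytotoxicity, read by MTT assay, with a stated time of 4 days; on this read-out higher numbers stand for lower toxicity in this test and lower numbers for higher toxicity in this test. For compound 1 the result is a limit of the assay, > 125000 nM, not a number. For the measured compounds named here, compound 2 is therefore the only compound with a number in this assay, where compound 2 gives 14800 nM. Going by the values given here, the one measured step, an at least 8.4-fold lower number from compound 1 to compound 2 (0.92 log units; beyond the scatter), runs against a limit of > 125000 nM in this assay, at which 1 of the 2 values shown sits, and is known only as a lower bound of its size.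

Compound 3 differs from compound 2 in one place: 3,5-dimethylphenyl in place of 3-carbamoylphenyl on a saturated chain carbon bound to an amine nitrogen in a ring. The change removes the carbamoyl group that entered in the measured step. Among the compounds with values here, only that step bears on it; it went to a lower number with the carbamoylphenyl, so the return to an aryl without the amide is expected to move the number back upward in this assay, by an amount that may be sizeable but cannot be fixed from a single bounded step. The step from compound 2 to compound 3 is estimated as a 4.1-fold higher number from compound 2 to compound 3 (0.61 log units; beyond the scatter). Compound 3 is accordingly expected to give about 60000 nM, within a range from 15000 nM to 125000 nM, with a real chance that only a limit is reported.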

Compound 3, half-maximal cytotoxic concentration: > 125000 nM
Compound 3: a limit, no number; the forecaster's own chance of this, stated with the estimate: 40%; middle value at least 2.0-fold (0.31 log units) from the limit.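

In this assay compound 3 gives > 125000 nM as a limit of the assay and not as a number. Putting 3,5-dimethylphenyl in place of 3-carbamoylphenyl, on a saturated chain carbon bound to an amine nitrogen in a ring, gives an at least 8.4-fold higher number from compound 2 to compound 3 (0.92 log units; beyond the scatter) and so sets the lower number of compound 2 against a second aryl group without the amide, where until now only the 4-(trifluoromethyl)phenyl of compound 1 stood against it. The step between compound 1 and compound 3 cannot be read, so these two aryl groups cannot be placed in any order, and the comparison at this position now runs up against the same limit twice: the limit of > 125000 nM in this assay, at which 2 of the 3 values shown sit.

What a carboxylic acid or an amine would give in place of the carbamoyl group on this phenyl ring stays open, so the compounds shown do not tell whether the lower number belongs to the carbamoyl group in particular. Also open, from the compounds shown here alone, is whether 4-carbamoylphenyl would go with a number like that of compound 2 or with a limit.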